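Chloro in place of methoxy on the shared core

A few compounds are considered here, and "the series" means these few. Any claim that something is new, unique, unknown or untested is made for them only; others in the source may bear on it.

Compound 1 `O=C(NO)c1ccc(CN2C(=O)/C(=C3\Nc4ccccc4\C3=N/O)c3cc(Br)ccc32)cc1`: 7 nM
Compound 2 `O=C(/C=C/c1ccc(CN2C(=O)/C(=C3\Nc4ccccc4\C3=N/O)c3cc(Cl)ccc32)cc1)NO`: 7 nM
Compound 3 `COc1ccc2c(c1)/C(=C1/Nc3ccccc3/C1=N\O)C(=O)N2Cc1ccc(C(=O)NO)cc1`: 90 nM

In a functional assay on NCI-H23 cells (Homo sapiens) for cytotoxicity, read by colorimetric assay (a lower number here means a stronger inhibitor, a higher number a weaker inhibitor), compound 3 gives the highest of the three numbers, and both compound 1 and compound 2 sit below it beyond the scatter. Compound 4 `O=C(NO)c1ccc(CN2C(=O)/C(=C3\Nc4ccccc4\C3=N/O)c3cc(Cl)ccc32)cc1` differs from compound 3 in one place: chloro in place of methoxy on an aromatic carbon. Among the measured compounds shown here, the one step that bears on this is the reverse direction of the same position, where bromo became methoxy and the number rose, a 13-fold higher number from compound 1 to compound 3 (1.11 log units; beyond the scatter). Compound 4 also carries the chloro found in compound 2, which gives 7 nM. A large drop is therefore expected, an 11-fold lower number from compound 3 to compound 4 (1.05 log units; beyond the scatter). Compound 4 is estimated at 8 nM, with a range from 3 nM to 25 nM.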

Compound 4, half-maximal inhibitory concentration: 50 nM
For compound 4 the middle estimate is 6.3-fold (0.80 log units) below the measured one; measured number outside the range, above it.
By their numbers in this assay, from the lowest: compounds 1 and 2 (each within the scatter of the next); then compounds 4 and 3 (each within the scatter of the next).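

In this assay chloro and methoxy on this aromatic carbon do not separate (a 1.8-fold lower number from compound 3 to compound 4 (0.26 log units; within the scatter)). Bromo does separate from chloro (a 7.1-fold higher number from compound 1 to compound 4 (0.85 log units; beyond the scatter)), so the earlier gap from methoxy is specific to bromo and is not shared by both halogens in this pair. The side chain matters as well, with hydroxycarbamoyl in place of 2-(hydroxycarbamoyl)ethenyl on the chloro compounds (a 7.1-fold higher number from compound 2 to compound 4 (0.85 log units; beyond the scatter)). Nothing available explains why bromo stands apart from chloro here.

Still open, as far as these compounds go, is whether an amine or a nitrile on this aromatic carbon would group with bromo or with chloro and methoxy. The compounds shown also leave open whether the 2-(hydroxycarbamoyl)ethenyl chain would give the same step with bromo or methoxy on the shared core.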